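A hex-1-en-1-yl chain in place of cyanosulfanyl

The compounds below may be only part of what the source reports. "The series", "measured", "known", "first", "only" and "open" are said of these compounds alone.

For the measured compounds named here, compound 1 `N#CSc1cn([C@H]2C[C@H](O)[C@@H](CO)O2)c(=O)[nH]c1=O` is the only compound with a number in an ADME assay on L1210/0 cells (Mus musculus) for cytotoxicity, with a stated time of 48 h (a lower number here means a stronger inhibitor, a higher number a weaker inhibitor), where compound 1 gives 78900 nM. Compound 2 `O=c1ccn(CC2CCC(CO)C2)c(=O)[nH]1` sits at the limit of > 200000 nM in this assay, at which 1 of the 2 values shown sits, and in this assay compound 2 gives > 200000 nM, which is a limit and not a number. Compound 3 `CCCC/C=C\c1cn([C@H]2C[C@H](O)[C@@H](CO)O2)c(=O)[nH]c1=O` differs from compound 1 by hex-1-en-1-yl in place of cyanosulfanyl on an aromatic carbon. Going by the values given here, no measured step is available, so the step in this assay is expected to be small, probably within the scatter, if anything toward a weaker inhibitor. Compound 3 is expected to give 60000 nM, within 12000 nM to 200000 nM. The expected step is a 1.3-fold lower number from compound 1 to compound 3 (0.12 log units; within the scatter).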

Compound 3, half-maximal inhibitory concentration: > 200000 nM
Compound 3 gave a limit, no number (the forecaster's own chance of this, stated with the estimate: 25%); middle value at least 3.3-fold (0.52 log units) from the limit.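

On this aromatic carbon, hex-1-en-1-yl in place of cyanosulfanyl gives an at least 2.5-fold higher number from compound 1 to compound 3 (0.40 log units; beyond the scatter) in this assay, so the group at this position does affect the read-out. Compound 3 gives a limit and not a number, so the step has a floor but no known size. Compound 3 also joins compound 2 at that limit: the limit of > 200000 nM in this assay, at which 2 of the 3 values shown sit.

As far as these compounds go, whether a shorter chain, an amine or a carboxylic acid at this position would keep the number of compound 1 stays open. So does whether any group here would lower it.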